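A few compounds are considered here, and "the series" means these few. Any claim that something is new, unique, unknown or untested is made for them only; others in the source may bear on it.

Compound 2 `CCc1cc(C(C)=O)c(O)cc1OCCCC(C)(C)c1nnn[nH]1` stands highest of the two numbers in hand: in an assay on isolated protein for binding affinity to leukotriene B4 receptor 1 (Homo sapiens), tested at 1 uM (on this read-out lower numbers stand for less inhibition and higher numbers for more inhibition at the one concentration tested (going by the name of the read-out)), compound 2 gives 76%, while compound 1 `CCc1cc(C(C)=O)c(O)cc1OCCCCCCC(C)(C)C#N` gives 30%. Among the measured compounds shown here, the one measured step, a number 46 percentage points higher from compound 1 to compound 2 (beyond the scatter), exchanges the whole chain end and does not isolate the two methyl groups. Compound 3 `CCc1cc(C(C)=O)c(O)cc1OCCCCc1nnn[nH]1` differs from compound 2 by (1H-tetrazol-5-yl)methyl in place of 1-(1H-tetrazol-5-yl)-1-methylethyl on a saturated chain carbon, three bonds along the chain from an oxygen on an aromatic ring. For the measured compounds named here, no measured step bears directly on this change, so a step no larger than the scatter, or a modest drop, is expected: a number 11 percentage points lower from compound 2 to compound 3 (beyond the scatter). For compound 3 the estimate is 65%, in the range 45% to 85%.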

Compound 3, a percentage reported as inhibition, at one concentration (the size of the read-out at that concentration, not a potency): 19%
Estimate against measurement, compound 3: 46 percentage points above; the whole stated range lies above it.
By their numbers in this assay, from the lowest: compound 3; then compound 1; then compound 2.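

In this assay, (1H-tetrazol-5-yl)methyl in place of 1-(1H-tetrazol-5-yl)-1-methylethyl gives a number 57 percentage points lower from compound 2 to compound 3 (beyond the scatter), so the two methyl groups matter at this position in the tetrazole series. In place of 3-cyano-3-methylbutyl, 1H-tetrazol-5-yl gives a number 11 percentage points lower from compound 1 to compound 3 (beyond the scatter), so the tetrazole ring alone does not bring the high read-out. Nothing available explains the size of the loss. Still open, as far as these compounds go, is whether a single methyl group keeps part of the read-out, and whether a carboxylic acid can replace the tetrazole with the two methyl groups in place.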